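Swapping the halogenated phenyl of compound 1

The compounds below may be only part of what the source reports. "The series", "measured", "known", "first", "only" and "open" are said of these compounds alone.

Measured compounds:
compound 1, `O=[N+]([O-])c1ccc(N/C(=N\O)c2ccccc2Br)c2nonc12`, 80 nM
compound 2, `O=[N+]([O-])c1ccc(N/C(=N\O)c2cccc(Br)c2)c2nonc12`, 105 nM

Both compounds were tested in an assay on isolated protein for inhibition of Indoleamine 2,3-dioxygenase 1 (Homo sapiens), read by spectrophotometry, with a stated time of 1 h; on this read-out higher numbers stand for weaker inhibition and lower numbers for stronger inhibition. Within the data shown here, compound 1 gives 80 nM and compound 2 gives 105 nM; the two values lie within the scatter of one another, the single measured step being a 1.3-fold higher number from compound 1 to compound 2 (0.12 log units; within the scatter), so compound 1 cannot be set apart from compound 2 on these numbers.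

Compound 3, `O=[N+]([O-])c1ccc(N/C(=N\O)c2ccc(F)c(Cl)c2)c2nonc12`, has not yet been measured in this assay. It differs from compound 1 as follows: 3-chloro-4-fluorophenyl in place of 2-bromophenyl on a carbon with a double bond to nitrogen. Among the measured compounds shown here, the only measured step that bears on this change is a 1.3-fold higher number from compound 1 to compound 2 (0.12 log units; within the scatter), which exchanged 2-bromophenyl for 3-bromophenyl on the same carbon and produced no shift beyond the scatter. For the measured compounds named here, no measured pair exchanges bromine for chlorine and fluorine or adds a second halogen to the ring, so the data give no ground for a larger step. Compound 3 is therefore expected to show no change beyond the scatter, a 1.2-fold lower number from compound 1 to compound 3 (0.09 log units; within the scatter). The estimate for compound 3 is 65 nM, with a range from 25 nM to 170 nM.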

Compound 3, half-maximal inhibitory concentration: 158 nM
For compound 3 the middle estimate is 2.4-fold (0.39 log units) below the measured one, and the stated range covers the measured number.
By their numbers in this assay, from the lowest: compounds 1, 2 and 3 (each within the scatter of the next).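

In this assay the change to 3-chloro-4-fluorophenyl gives a 2.0-fold higher number from compound 1 to compound 3 (0.30 log units; within the scatter) and a 1.5-fold higher number from compound 2 to compound 3 (0.18 log units; within the scatter) and so separates compound 3 from neither earlier compound. The earlier step had only moved a single bromine around the phenyl ring, whereas this change exchanges bromine for chlorine and fluorine and puts two halogens on the ring, and the number on this carbon with a double bond to nitrogen still stays within the scatter for all three compounds. Nothing available explains why these three halogenated phenyl groups read alike.

As far as these compounds go, all three compounds carry a halogenated phenyl at this place, so it remains open how the read-out would respond to a phenyl ring without halogen or to a ring bearing an amine or a carboxylic acid. It also remains open whether any exchange on this carbon can move the number beyond the scatter at all, since the steps shown give no measure of how far this position can shift it.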